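Amino substitution on the bicyclic core: notes on cytotoxicity

A few compounds are considered here, and "the series" means these few. Any claim that something is new, unique, unknown or untested is made for them only; others in the source may bear on it.

Compound 1 `ClCc1ccc(Cn2cnc3c(Cl)ncnc32)cc1` and compound 3 `ClCc1ccccc1Cn1cnc2c(Cl)ncnc21` share the same atoms joined differently; the difference between the two cores is not broken down here. In a functional assay on A549 cells (Homo sapiens) for cytotoxicity, read by sulforhodamine B assay, with a stated time of 48 h (on this read-out lower numbers stand for stronger inhibition of growth and higher numbers for weaker inhibition of growth), compound 1 gives 18200 nM, and compound 3 gives 25700 nM, the two within the usual scatter of each other. Compound 2 `Nc1nc(Cl)c2ncn(Cc3ccc(CCl)cc3)c2n1` carries one change relative to compound 1, (amino in place of hydrogen on an aromatic carbon). In this assay compound 2 gives 75900 nM, which is a 4.2-fold higher number from compound 1 to compound 2 (0.62 log units; beyond the scatter), a step beyond the scatter.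

Compound 4 `Nc1nc(Cl)c2ncn(Cc3ccccc3CCl)c2n1` stands to compound 3 as compound 2 stands to compound 1: the change is amino in place of hydrogen on an aromatic carbon, and its place matches that of the earlier change word for word, so it is the same change made on the core of compound 3. Within the data shown here, only one instance of it is measured, so the expectation rests on that single step. From compound 3 the expected step is a 3.9-fold higher number from compound 3 to compound 4 (0.59 log units; beyond the scatter), chosen to match a 4.2-fold higher number from compound 1 to compound 2 (0.62 log units; beyond the scatter) in size and direction. In this assay compound 4 is therefore estimated at 100000 nM, with a likely range from 40000 nM to 250000 nM.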

Compound 4, concentration for total growth inhibition: 53700 nM
The estimate for compound 4 lay 1.9-fold (0.27 log units) above the measured number; the range from low to high includes it.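

On the core of compound 3, amino in place of hydrogen on an aromatic carbon gives a 2.1-fold higher number from compound 3 to compound 4 (0.32 log units; beyond the scatter) in this assay. The number rises on both cores, and the two steps do not differ beyond what repeated measurements allow: the same change on two cores in this assay, a 4.2-fold higher number (0.62 log units; beyond the scatter) from compound 1 to compound 2 and a 2.1-fold higher number (0.32 log units; beyond the scatter) from compound 3 to compound 4, 2.0-fold (0.30 log units) apart, within the scatter of two such steps. For these two pairs, the change carries from one core to the other in direction and, within the scatter, in size; this does not show that it would carry to any further core, and it says nothing of why the number rises.

The compounds shown leave open whether another group in the same place, between two ring nitrogen atoms, such as methylamino or hydroxyl, would shift the number in the same way as amino. Also open, as far as these compounds go, is what replacing the chloromethyl group with hydroxymethyl or a longer chain would do on either core, and whether the amino step would then stay the same.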